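The compounds below may be only part of what the source reports. "The series", "measured", "known", "first", "only" and "open" are said of these compounds alone.

Measured so far in an assay for inhibition of protein kinase C iota type (Homo sapiens), read by mobility shift assay, with a stated time of 60 min; a lower number here means a stronger inhibitor, a higher number a weaker inhibitor:
compound 1 `Nc1nccnc1C(=O)Nc1ccncc1`, 23000 nM
compound 2 `CC(C)(C)c1cc(NC(=O)c2nccnc2N)ccn1`, 24000 nM

Compound 2 and compound 1 stand within the scatter of each other, the step of a 1.0-fold higher number from compound 1 to compound 2 (0.02 log units; within the scatter) showing that tert-butyl in place of hydrogen on this aromatic carbon left the number unchanged. Compound 3 `Nc1nccnc1C(=O)Nc1ccnc(Br)c1` carries bromo in place of tert-butyl on an aromatic carbon. That single step is the only measured one bearing on this position, and it was flat, so no step beyond the scatter is expected in this assay: no change at the digits printed from compound 2 to compound 3 (within the scatter). Compound 3 is therefore estimated at 24000 nM, with a range of 8000 nM to 70000 nM.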

Compound 3, half-maximal inhibitory concentration: > 384000 nM
Compound 3: no number, only a limit (the forecaster's own chance of this, stated with the estimate: 20%); at least 16-fold (1.20 log units) between middle value and limit.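

In this assay, the position next to the ring nitrogen turns out not to be indifferent to its substituent: bromo in place of tert-butyl gives an at least 16-fold higher number from compound 2 to compound 3 (1.20 log units; beyond the scatter), and bromo in place of hydrogen gives an at least 16-fold higher number from compound 1 to compound 3 (1.22 log units; beyond the scatter). The flat exchange of hydrogen for tert-butyl therefore does not extend to every group here, and of the three groups shown only bromo moves the number. Compound 3 gives a limit, not a number: the limit of > 384000 nM in this assay, at which 1 of the 3 values shown sits.

As far as these compounds go, the full size of both steps stays open. Also open, from the compounds shown here alone, is whether chloro, methoxy or an amine at this position would match hydrogen and tert-butyl or follow bromo.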